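The source may report more compounds than this note shows. Statements on the series, on what has been measured and on what is new or still open speak of the compounds shown alone.

Measured so far:
Compound 1, `Cc1cc(C)c(/N=C(\NC#N)NC(C)(C)C)c(C)n1`, in a functional assay on the whole organism (blood, strain Wistar-Okamoto) with Rattus norvegicus as the target, with a stated time of 5 days (on this read-out higher numbers stand for an effect only at larger amounts of compound and lower numbers for an effect already at smaller amounts), compound 1 gives only a limit, > 50 mg/kg.
Compound 2, `CCC(/N=C(\NC#N)Nc1ccncc1)C(C)C`, in this assay compound 2 gives 5 mg/kg.
Compound 3, `CC(C)C(/N=C(\NC#N)Nc1ccncc1)C(C)C`, in this assay compound 3 gives 8 mg/kg.

Among the two numbers that are numbers, compound 2 holds the lower one; its nearest neighbour is compound 3, and the step of a 1.6-fold higher number from compound 2 to compound 3 (0.20 log units; within the scatter) stays within the scatter, so the two cannot be ranked. The remaining value is the limit of > 50 mg/kg in this assay, at which 1 of the 3 values shown sits, and it is a limit rather than a number.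

The compound not yet measured is compound 4, `N#CN/C(=N\c1ccccc1)Nc1ccncc1`. It differs from compound 2 in one place: phenyl in place of 1-isopropylpropyl on a double-bonded nitrogen. Within the data shown here, the only measured step, from compound 2 to compound 3, alters the saturated chain and says nothing about exchanging that chain for an aromatic ring; no measured pair covers this change. The expectation therefore rests on compound 2 alone, widened for the unknown. For compound 4 the expected step is a 2.4-fold higher number from compound 2 to compound 4 (0.38 log units; beyond the scatter), an estimate of 12 mg/kg, with a range from 3 mg/kg to 50 mg/kg.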

Compound 4, minimum effective dose: 50 mg/kg
The estimate for compound 4 lay 4.2-fold (0.62 log units) below the measured number; the measured number falls inside the stated range.
By their numbers in this assay, from the lowest: compounds 2 and 3 (each within the scatter of the next); then compound 4.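

In this assay, phenyl in place of 1-isopropylpropyl on a double-bonded nitrogen gives a step beyond the scatter: a 10-fold higher number from compound 2 to compound 4 (1.00 log units; beyond the scatter). The earlier change within the saturated chain stayed within the scatter, a 1.6-fold higher number from compound 2 to compound 3 (0.20 log units; within the scatter), so the position tolerated that small change but not this exchange of the whole group. The two groups have the same count of heavy atoms and neither has hydrogen-bond donors or acceptors, and nothing shown here accounts for the difference between them.

Going by these compounds, it remains open whether the higher number follows from the ring as such or from its being aromatic, which a cyclohexyl group at this position could separate. On these data alone, it is also open whether a chlorine or methoxy group on the phenyl ring would shift the number in either direction.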